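The compounds below may be only part of what the source reports. "The series", "measured", "known", "first", "only" and "open" are said of these compounds alone.

In an assay on mitochondria (strain Sprague-Dawley) for inhibition of Amine oxidase [flavin-containing] B (Rattus norvegicus), read by fluorescence and Amplex Red, with stated times of 30 min and 45 min (a lower number here means a stronger inhibitor, a higher number a weaker inhibitor), compound 1 `O=C(CCc1ccccc1)Nc1nc2ccccc2c(=O)s1` gives 42.7 nM; compound 2 `O=C(CCCc1cccc(Cl)c1)Nc1nc2ccccc2c(=O)s1` gives 6880 nM.

Compound 2 stands highest of the two numbers, and its nearest neighbour is compound 1, which shows a 160-fold higher number from compound 1 to compound 2 (2.21 log units; beyond the scatter). Compound 3 `O=C(CCc1ccc(Cl)c(Cl)c1)Nc1nc2ccccc2c(=O)s1` differs from compound 2 by 3,4-dichlorophenyl in place of 3-chlorobenzyl on a saturated chain carbon, two bonds along the chain from a carbonyl carbon. Going by the values given here, the only step that bears on this change is the one from compound 1 to compound 2, which was large, and compound 3 returns to the chain length of compound 1 while carrying two chlorines on the ring. A large drop in the number is therefore expected. Compound 3 is estimated at 80 nM, with a range of 15 nM to 600 nM. The expected step is an 86-fold lower number from compound 2 to compound 3 (1.93 log units; beyond the scatter).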

Compound 3, half-maximal inhibitory concentration: > 10000 nM
Compound 3 was reported as a limit (the forecaster's own chance of this, stated with the estimate: 5%); middle value at least 120-fold (2.09 log units) away from the limit.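

Compound 3 is reported in this assay only as a limit: the limit of > 10000 nM in this assay, at which 1 of the 3 values shown sits. With 3,4-dichlorophenyl in place of phenyl at this chain carbon, the data show an at least 230-fold higher number from compound 1 to compound 3 (2.36 log units; beyond the scatter), so a large rise in the number occurs here without the 3-chlorobenzyl of compound 2. The other comparison, an at least 1.4-fold higher number from compound 2 to compound 3 (0.16 log units; that floor lies within the scatter), gives only a floor, so compound 2 and compound 3 cannot be ordered.

The compounds shown leave open how 3-chlorophenyl or unsubstituted benzyl would read at this place. The separate contributions of ring chlorine and chain length therefore remain unresolved.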